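A halogen swap on the aryl ether of compound 2

The compounds below may be only part of what the source reports. "The series", "measured", "known", "first", "only" and "open" are said of these compounds alone.

Among the compounds with values here, compound 2 `NC1=NC2(CCSCC2)N(OCCCOc2ccc(Cl)cc2)C(N)=N1` stands lowest of the three numbers measured so far. In a functional assay on HCT-116 cells (Homo sapiens) for antiproliferative activity, read by MTT assay, with a stated time of 72 h (a lower number here means a stronger inhibitor, a higher number a weaker inhibitor), compound 2 gives 10 nM. Compound 1 `Cc1ccc(OCCCON2C(N)=NC(N)=NC23CCOCC3)cc1` gives 2390 nM in this assay, and compound 3 `CC(C)(C)c1ccc(OCCCON2C(N)=NC(N)=NC23CCOCC3)cc1` gives 1610 nM in this assay; both sit beyond the scatter from compound 2, and both differ from compound 2 in the core as well as in the aryl group, so neither isolates any single change. Within the data shown here, the only measured step, a 1.5-fold lower number from compound 1 to compound 3 (0.17 log units; within the scatter), concerns tert-butyl in place of methyl on an aromatic carbon and lies within the scatter.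

Compound 4 `NC1=NC2(CCSCC2)N(OCCCOc2cccc(Br)c2)C(N)=N1` differs from compound 2 by 3-bromophenyl in place of 4-chlorophenyl on an oxygen on a saturated carbon. Among the measured compounds shown here, no measured pair bears directly on this change, and the one step that exists shows an aryl substituent being varied without a shift beyond the scatter. One therefore expects compound 4 to stay close to compound 2, with the step of a 3.0-fold higher number from compound 2 to compound 4 (0.48 log units; beyond the scatter) estimated as small and slightly toward a higher number. The estimate for compound 4 in this assay is 30 nM, within a range of 8 nM to 150 nM.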

Compound 4, half-maximal inhibitory concentration: 1 nM
Compound 4: middle estimate off by 30-fold (1.48 log units), on the high side, and the stated range ends above it.
By their numbers in this assay, from the lowest: compound 4; then compound 2; then compounds 3 and 1 (each within the scatter of the next).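

In this assay, the change from 4-chlorophenoxy to 3-bromophenoxy gives a 10-fold lower number from compound 2 to compound 4 (1.00 log units; beyond the scatter), so the aryl group at this place can move the number beyond the scatter on the shared core of compound 2 and compound 4. Within the data shown here, the only earlier step, a 1.5-fold lower number from compound 1 to compound 3 (0.17 log units; within the scatter), varied an aryl substituent on a different core and stayed within the scatter, so it gave no sign of this sensitivity. The step changes the halogen and its ring position together, and nothing available here explains the shift.

On these data alone, whether the shift follows the bromine or its ring position remains open, and a 3-chlorophenyl or a 4-bromophenyl group on this core would separate the two. Also open, as far as these compounds go, is whether 3-bromophenyl has the same effect on the core of compound 1, and how an amine at this ring position would compare.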